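The source may report more compounds than this note shows. Statements on the series, on what has been measured and on what is new or still open speak of the compounds shown alone.

Measured so far:

- Compound 3, `CCCOC(=O)Nc1ccc([Se]C#N)cc1`, in an ADME assay on BEAS-2B cells (Homo sapiens) for cytotoxicity, read by MTT assay, with a stated time of 72 h (on this read-out higher numbers stand for weaker inhibition of growth and lower numbers for stronger inhibition of growth), gives 46300 nM.
- Compound 1, `COc1ccc(OC(=O)Nc2ccc([Se]C#N)cc2)cc1`, gives 48400 nM.
- Compound 2, `CC(C)COC(=O)Nc1ccc([Se][Se]c2ccc(NC(=O)OCC(C)C)cc2)cc1`, gives 42700 nM.

Compound 3 sits second highest of the three numbers, but its nearest neighbour, compound 1, and its furthest, compound 2, both lie within the usual scatter of it, so the three compounds cannot be told apart on this read-out. In each the carbamate carries a different chain or a different selenium group, and the numbers still stay close.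

Compound 4, `CCCCOC(=O)Nc1ccc([Se]C#N)cc1`, is reached from compound 3 by a single change: methyl in place of hydrogen on a saturated chain carbon, three bonds along the chain from an oxygen next to a carbonyl group. For the measured compounds named here, no measured pair shows the effect of this change, so the expectation rests on how little the three measured compounds differ from one another. The step from compound 3 to compound 4 is therefore expected to be a 1.0-fold lower number from compound 3 to compound 4 (0.00 log units; within the scatter), that is, none beyond the scatter. Compound 4 is estimated at 46000 nM, with a range from 25000 nM to 85000 nM.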

Compound 4, concentration for total growth inhibition: 12200 nM
Beside the measured number, compound 4's estimate is 3.8-fold (0.58 log units) above it, and the stated range ends above it.
By their numbers in this assay, from the lowest: compound 4; then compounds 2, 3 and 1 (each within the scatter of the next).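

Going from propyl to butyl, methyl in place of hydrogen at this place on the chain gives the first step in this set that lies beyond the scatter: in this assay there is a 3.8-fold lower number from compound 3 to compound 4 (0.58 log units; beyond the scatter). The change adds only one carbon, yet it shows that the chain end of the carbamate can matter for growth inhibition of these cells, which the closely grouped numbers of compound 1, compound 2 and compound 3 gave no sign of. Nothing measured here accounts for this step.

Going by these compounds, a single step on one chain cannot show a trend, so it stays open whether a longer chain such as hexyl would bring the number lower still or back up. On these data alone, it is equally open whether a branched chain such as isobutyl, or a hydroxyl group at the chain end, would keep the effect.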